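Maleimide-type series: cytotoxicity limits and one amide-cap change

The compounds below may be only part of what the source reports. "The series", "measured", "known", "first", "only" and "open" are said of these compounds alone.

Measured compounds:
compound 1 `Cc1ccc(N2C(=O)C/C(=C\c3cccc(C(=O)Nc4cccc(F)c4)c3)C2=O)cc1`: > 100000 nM
compound 2 `Cc1ccc(NC(=O)c2cccc(/C=C3\CC(=O)N(c4ccccc4)C3=O)c2)cc1C`: > 100000 nM
compound 3 `CCCCCN1C(=O)C/C(=C\c2cccc(C(=O)NCCCC)c2)C1=O`: > 100000 nM

In an ADME assay on HCT-116 cells (Homo sapiens) for cytotoxicity, read by MTT assay, with a stated time of 72 h (a higher number here means a weaker inhibitor, a lower number a stronger inhibitor), compound 2 gives only > 100000 nM, which is a limit of the assay and not a number. Compound 1 likewise gives only the limit > 100000 nM in this assay. Compound 3 sits at the limit > 100000 nM in this assay as well. Nothing separates the three on these numbers; the common feature is the limit of > 100000 nM in this assay, at which 3 of the 3 values shown sit, so compound 2 stands exactly where every measured compound stands, with no number to rank it against the others.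

Compound 4 `O=C(Nc1ccc(F)cc1)c1cccc(/C=C2\CC(=O)N(c3ccccc3)C2=O)c1` has not yet been measured in this assay. It differs from compound 2 in one place: 4-fluorophenyl in place of 3,4-dimethylphenyl on an amide-type nitrogen.

Going by the values given here, with all three measured values sitting at the limit, there is no measured step of any size, in either direction, to build on. Among the compounds with values here, the change in the amide cap has no counterpart among measured pairs. The expected outcome is that the step of a number no higher from compound 2 to compound 4 (the limit leaves the size open) is none beyond the scatter. Compound 4 is therefore expected to give about 100000 nM in this assay, between 40000 nM and 300000 nM, most likely reported as a limit once more.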

Compound 4, half-maximal inhibitory concentration: > 100000 nM
Compound 4 gave a limit, no number; the forecaster's own chance of this, stated with the estimate: 85%; the middle value lies on the limit itself.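

Compound 2 and compound 4 both give only a limit in this assay and no number, so no step between them can be read: the limit of > 100000 nM in this assay, at which 4 of the 4 values shown sit.

The compounds shown leave open whether any change to the amide cap or the shared core gives a readable number in this assay at all.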